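The source may hold more compounds than are shown below. What is called first, only, known or untested is meant among the compounds shown, and "the series" means these compounds.

The series shares the furanone core of compound 1 `O=C1O/C(=C\Cn2ncc(=O)[nH]c2=O)C(OCc2ccccc2)=C1OCc1ccccc1`, with two benzyloxy groups and a side chain that carries a heterocycle. In a functional assay on SW-620 cells (Homo sapiens) for inhibition, read by MTT assay, with a stated time of 72 h (on this read-out lower numbers stand for stronger inhibition and higher numbers for weaker inhibition), compound 1 gives 36500 nM. Compound 2 `Nc1ncn(C/C=C2\OC(=O)C(OCc3ccccc3)=C2OCc2ccccc2)c(=O)n1` gives 5620 nM in this assay, and the step of a 6.5-fold lower number from compound 1 to compound 2 (0.81 log units; beyond the scatter). Compound 3 `NC1(CCn2cc(F)c(=O)[nH]c2=O)OC(=O)C(OCc2ccccc2)=C1OCc1ccccc1`, whose side chain is saturated and carries an amino group, returns only a limit in this assay, > 100000 nM, as recorded by the limit of > 100000 nM in this assay, at which 1 of the 3 values shown sits. Among the numbers given, compound 2 stands lowest, with compound 1 nearest; the third value is a limit and not a number.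

Compound 4 `O=C1O/C(=C\Cn2c(=O)[nH]c(=O)[nH]c2=O)C(OCc2ccccc2)=C1OCc1ccccc1` is yet to be measured in this assay. Relative to compound 2 the change is a group of 9 heavy atoms (3 carbon, 3 nitrogen, 3 oxygen; one six-membered aromatic ring with 3 hetero atoms) in place of a group of 8 heavy atoms (3 carbon, 4 nitrogen, 1 oxygen; one six-membered aromatic ring with 3 hetero atoms), on a saturated chain carbon bound to a double-bonded chain carbon. Among the measured compounds shown here, one measured step bears on this position, the exchange of the heterocycle on the same chain carbon, a 6.5-fold lower number from compound 1 to compound 2 (0.81 log units; beyond the scatter), which was modest though beyond the scatter. A change of comparable size is therefore expected here, and since compound 2 is the lowest number, the more likely direction is upward, toward compound 1. Compound 4 is expected at 20000 nM, within 5000 nM to 80000 nM. This estimate corresponds to a step of a 3.6-fold higher number from compound 2 to compound 4 (0.55 log units; beyond the scatter).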

Compound 4, half-maximal inhibitory concentration: > 100000 nM
Compound 4: only a limit was reported; the forecaster's own chance of this, stated with the estimate: 15%; middle value at least 5.0-fold (0.69 log units) away from the limit.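

In this assay compound 4 gives > 100000 nM, which is a limit and not a number. On the saturated chain carbon bound to a double-bonded chain carbon, exchanging one six-membered aromatic ring with 3 hetero atoms for another can move the read-out further than a 6.5-fold lower number from compound 1 to compound 2 (0.81 log units; beyond the scatter) alone showed: the new steps, both read from that limit, are an at least 17-fold higher number from compound 2 to compound 4 (1.25 log units; beyond the scatter) and an at least 2.7-fold higher number from compound 1 to compound 4 (0.43 log units; beyond the scatter). Among the heterocycles at this place, the one in compound 2 now stands apart from those in compound 1 and compound 4, and the series reaches the limit a second time: the limit of > 100000 nM in this assay, at which 2 of the 4 values shown sit.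

How far compound 4 lies from compound 2 remains unresolved, as the steps that rest on its limit give only a minimum size. Also open, from the compounds shown here alone, is whether an amine or a carboxylic acid in place of the heterocycle on this chain carbon, or a longer chain carrying the heterocycle of compound 2, would hold the read-out near that of compound 2 or lose it as well.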